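This account rests on a few compounds, and the source may have more. Where it says the series, first, only, none or still open, it means among the compounds named here.

Going by the values given here, the series shares one core, and the two measured members differ only in the group on the five-membered ring. Compound 1 `CCCC(Oc1ccc(-n2cc(OC)cn2)cc1)c1ccc(C(=O)NCCC(=O)O)cc1` carries a methoxy there, and in a functional assay on cells for antagonist activity at Glucagon receptor (Homo sapiens), read by cAMP accumulation, in the presence of a further agent that is not named here (on this read-out lower numbers stand for stronger inhibition and higher numbers for weaker inhibition), compound 1 reaches only a limit of the assay, > 23000 nM, which is the limit of > 23000 nM in this assay, at which 1 of the 2 values shown sits. Compound 2 `CCCC(Oc1ccc(-n2cc(F)cn2)cc1)c1ccc(C(=O)NCCC(=O)O)cc1` carries a fluoro in the same place, and in this assay compound 2 gives 10000 nM. Among the compounds with values here, the move an at least 2.3-fold lower number from compound 1 to compound 2 (0.36 log units; beyond the scatter) is the only measured step, and it was brought about by fluoro in place of methoxy on an aromatic carbon. Within this assay compound 2 therefore stands as the only plain number shown, the one further value being a limit.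

Compound 3 `CCCC(Oc1ccc(-n2cc(C)cn2)cc1)c1ccc(C(=O)NCCC(=O)O)cc1` differs from compound 2 by methyl in place of fluoro on an aromatic carbon. Within the data shown here, no measured step covers methyl against fluoro, so the one step from compound 1 to compound 2 gives only a loose guide, and with a single anchor no direction is supported. The step of a 1.2-fold higher number from compound 2 to compound 3 (0.08 log units; within the scatter) is expected to stay within the scatter. Compound 3 is accordingly estimated at 12000 nM in this assay, with a range from 4000 nM to 30000 nM.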

Compound 3, antagonist equilibrium constant: 11000 nM
For compound 3 the middle estimate is 1.1-fold (0.04 log units) above the measured one; the range from low to high includes it.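

In this assay, the move a 1.1-fold higher number from compound 2 to compound 3 (0.04 log units; within the scatter) shows that methyl and fluoro cannot be told apart at this place on the five-membered aromatic ring, even though a carbon now stands where a fluorine stood. Going by these compounds alone, the move an at least 2.0-fold lower number from compound 1 to compound 3 (0.32 log units; beyond the scatter) adds a second group that lies beyond the scatter from methoxy, so the earlier gain no longer belongs to fluoro alone, and what separates the three compounds so far is methoxy against the other two groups. The size of both steps from methoxy stays open-ended, since compound 1 is only a limit of the assay: the limit of > 23000 nM in this assay, at which 1 of the 3 values shown sits.

The compounds shown leave open whether plain hydrogen, an ethyl, a trifluoromethyl, a nitrile or an amine at this place would read like methyl and fluoro or move the number in either direction. They also leave open whether any group at this place can shift the number much further, or whether that would take a change elsewhere on the shared core, such as a longer chain.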